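This account rests on a few compounds, and the source may have more. Where it says the series, first, only, none or still open, it means among the compounds named here.

Series notes. The shared core is held fixed and the measured members differ only in the group on the six-membered aromatic ring of carbon only. Compound 1 `CCC(C)(C)Cc1c[nH]c(CCc2ccc(-c3ccncc3)cc2)n1` gives 305 nM in a functional assay on HEK293 cells for agonist activity at Bombesin receptor subtype-3 (Homo sapiens), read by luminescence and calcium flux, with a stated time of 10 min; on this read-out lower numbers stand for an effect already at smaller amounts and higher numbers for an effect only at larger amounts of compound. Compound 2 `CCC(C)(C)Cc1c[nH]c(CCc2ccc(-n3ncnn3)cc2)n1` gives 422 nM in this assay, and compound 3 `CCC(C)(C)Cc1c[nH]c(CCc2ccc(-c3cccnc3C(=O)O)cc2)n1` gives 1260 nM in this assay. Compound 1 sits at the low end of the three numbers; compound 2 lies within the scatter of it, compound 3 beyond it. The single-point steps are a 1.4-fold higher number from compound 1 to compound 2 (0.14 log units; within the scatter), a 4.1-fold higher number from compound 1 to compound 3 (0.62 log units; beyond the scatter) and a 3.0-fold higher number from compound 2 to compound 3 (0.48 log units; beyond the scatter).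

Compound 4 `CCC(C)(C)Cc1c[nH]c(CCc2ccc(-c3ccns3)cc2)n1` has not been measured. Its change from compound 1: 1,2-thiazol-5-yl in place of pyridin-4-yl on an aromatic carbon. The step that bears on it most is a 1.4-fold higher number from compound 1 to compound 2 (0.14 log units; within the scatter), where a five-membered aromatic ring likewise replaced pyridin-4-yl. Among the compounds with values here, the only step beyond the scatter, a 4.1-fold higher number from compound 1 to compound 3 (0.62 log units; beyond the scatter), belongs to a group of another kind and carries less weight here. Nothing in the data separates 1,2-thiazol-5-yl from 2H-tetrazol-2-yl. A step no larger than the scatter is therefore expected, if anything toward a higher number: a 1.3-fold higher number from compound 1 to compound 4 (0.12 log units; within the scatter). Compound 4 is estimated at 400 nM, with a range from 150 nM to 1200 nM.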

Compound 4, half-maximal effective concentration: 63 nM
Compound 4: the middle estimate sits 6.3-fold (0.80 log units) above what was measured; the measured number lies below the stated range.
By their numbers in this assay, from the lowest: compound 4; then compounds 1 and 2 (each within the scatter of the next); then compound 3.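

With 1,2-thiazol-5-yl on this aromatic carbon, para to a large group, the position proves able to move the number down beyond the scatter in this assay (a 4.8-fold lower number from compound 1 to compound 4 (0.68 log units; beyond the scatter)), whereas the earlier replacements of pyridin-4-yl gave a step within the scatter or one toward a higher number. Two five-membered aromatic rings are also clearly separated here (a 6.7-fold lower number from compound 2 to compound 4 (0.83 log units; beyond the scatter)), so ring size alone does not set the number at this place, and the span across the groups shown now reaches a large step (a 20-fold lower number from compound 3 to compound 4 (1.30 log units; beyond the scatter)). No measurement shown offers an explanation for why 1,2-thiazol-5-yl stands apart from the other groups.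

The compounds shown leave open whether the ring sulfur or the ring nitrogen matters more for this result, a question that 1,2-oxazol-5-yl and thiophen-2-yl at the same place would address. They also leave open whether the lower number of compound 4 would hold with a shorter chain in place of the branched alkyl chain on the shared core.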